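Bromo for methyl on the fused ring of compound 3

The source may hold more compounds than are shown below. What is called first, only, known or untested is meant among the compounds shown, and "the series" means these compounds.

Working notes on a small set of flavone-bearing compounds in a functional assay on MCF7 cells (Homo sapiens) for inhibition, read by MTT assay, with a stated time of 48 h, tested at 30 ug/mL; a lower number here means less inhibition of growth, a higher number more inhibition of growth at the concentration tested. Compound 1 `Cc1cc(C)c2c(c1)CN(c1ccc3c(=O)cc(-c4ccccc4)oc3c1)CO2` gives 26.8%; compound 2 `O=c1cc(-c2ccccc2)oc2cc(N3COc4c(cccc4[N+](=O)[O-])C3)ccc12` gives 5.65%; compound 3 `Cc1cccc2c1OCN(c1ccc3oc(-c4ccccc4)cc(=O)c3c1)C2` gives 72.4%. Compound 3 thus stands highest of the three: compound 1 lies nearest and is lower by a gap beyond the scatter, compound 2 furthest and lower by a wider gap. Compound 4 `O=c1cc(-c2ccccc2)oc2ccc(N3COc4c(Br)cccc4C3)cc12` differs from compound 3 by bromo in place of methyl on an aromatic carbon. For the measured compounds named here, no measured pair shows this exchange, so the size of the step is open; the expected step from compound 3 to compound 4 is a number 22.4 percentage points lower from compound 3 to compound 4 (beyond the scatter), a moderate drop. Compound 4 is estimated at 50%, within 20% to 78%.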

Compound 4, percent growth inhibition at one concentration: 71.6%
Estimate against measurement, compound 4: 21.6 percentage points below; the range from low to high includes it.
By their numbers in this assay, from the lowest: compound 2; then compound 1; then compounds 4 and 3 (each within the scatter of the next).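

In this assay, bromo in place of methyl on this aromatic carbon gives a number 0.8 percentage points lower from compound 3 to compound 4 (within the scatter). For the compounds shown here, this is the first exchange that can be read at a single place, and here the two groups cannot be told apart by growth inhibition at the concentration tested. No measured information bears on this result. From the compounds shown here alone, whether an amine, a hydroxyl or a carboxylic acid on this carbon would keep the read-out at the level of compound 3 and compound 4 stays open. Going by these compounds, whether the same exchange behaves alike on the core of compound 1 also stays open.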